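The compounds below may be only part of what the source reports. "The series", "measured", "known", "first", "only" and "open" are said of these compounds alone.

Compound 1 `CC(C)(C)c1conc1N1C(=O)CSC1c1cccc(C(=O)NCCCCc2ccccc2)c1` is the starting point of this account. In a functional assay on HOS-TE85 cells (Homo sapiens) for inhibition, read by CCK-8 assay, with a stated time of 72 h (a higher number here means a weaker inhibitor, a lower number a stronger inhibitor), compound 1 gives only a limit, > 1000 nM, and not a number. Compound 3 `O=C(NCCCCn1cccn1)c1cccc(C2SCC(=O)N2c2ccncc2)c1` likewise reaches only a limit in this assay, > 1000 nM. Going by the values given here, compound 2 `CC1SC(c2cccc(C(=O)NCCCCc3ccc(Cl)cc3)c2)N(c2cccc(C3CC3)c2)C1=O` is the one member of the set with a numerical result, giving 932 nM in this assay. So compound 1 stands at the edge of what this assay can resolve, and the limit of > 1000 nM in this assay, at which 2 of the 3 values shown sit, shows that it shares that position with most of what has been measured here.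

The unmeasured compound 4 `CC(F)(F)c1cccc(N2C(=O)CSC2c2cccc(C(=O)NCCCCc3ccccc3)c2)c1` differs from compound 1 at a single position: a group of 10 heavy atoms (8 carbon, 2 fluorine; one six-membered aromatic ring of carbon only) in place of a group of 9 heavy atoms (7 carbon, 1 nitrogen, 1 oxygen; one five-membered aromatic ring with 2 hetero atoms), on an amide-type nitrogen in a ring. Among the compounds with values here, no pair among the measured compounds differs in only one place, so no measured step gives a direct guide to the size of this change.

With compound 1 known only as a limit, and with compound 2 sitting close to that same limit, the expectation for compound 4 is modest. The step of an at least 1.1-fold lower number from compound 1 to compound 4 (0.04 log units; that floor lies within the scatter) is expected to be small, with the result landing near the limit rather than far below it. Compound 4 is therefore estimated at 900 nM in this assay, with a range from 250 nM to 3000 nM.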

Compound 4, half-maximal inhibitory concentration: 29.1 nM
Estimate against measurement, compound 4: 31-fold (1.49 log units) above, outside the stated range (below it).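

At the amide-type nitrogen in a ring, a group with one six-membered aromatic ring of carbon only and 2 fluorine atoms, in place of a group with one five-membered aromatic ring with 2 hetero atoms, gives an at least 34-fold lower number from compound 1 to compound 4 (1.53 log units; beyond the scatter) in this assay. Going by these compounds alone, the earlier compounds included no pair differing in one place, so this is the first sign that a change at this position alone can carry a large step, with the rest of the core of compound 1 and its side chain kept as they stand. Compound 4 also gives a number well clear of the edge of what the assay resolves, and the change takes this structure away from: the limit of > 1000 nM in this assay, at which 2 of the 4 values shown sit.

The compounds shown leave open which part of the entering group carries the step, the carbon-only aromatic ring or its fluorine atoms, and a version of that ring carrying an ethyl, a trifluoromethyl or a nitrile would separate the two. They also leave open whether the same step would appear with a different chain on the amide, such as the pyrazole-bearing butyl chain's carbon-only counterpart with an amine at its end.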